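The source may report more compounds than this note shows. Statements on the series, on what has been measured and on what is new or still open speak of the compounds shown alone.

Compound 1 `CC(C)C(=O)N1CCC(NC(=O)Nc2ccc(C(F)(F)F)c(F)c2)CC1` and compound 2 `CC(C)C(=O)N1CCC(NC(=O)Nc2ccc(OC(F)(F)F)c(F)c2)CC1` share one core and differ in a single place. The change from compound 1 to compound 2 is trifluoromethoxy in place of trifluoromethyl on an aromatic carbon. In a physicochemical assay for lipophilicity, read by HPLC, with a stated time of 90 min, tested at 100 uM (a lower number here means a more polar compound, a higher number a more lipophilic compound), compound 1 gives 4.4 and compound 2 gives 4.73, so this swap produced a number 0.33 log units higher from compound 1 to compound 2 (beyond the scatter).

Compound 3 `O=C(Nc1ccc(C(F)(F)F)cc1)NC1CCN(C(=O)c2ccoc2)CC1` is built on a different core; how the core of compound 3 differs from the core of compound 1 is not broken down here. In this assay compound 3 gives 3.5, the lowest of the three numbers, with compound 1 the nearest to it and compound 2 the furthest away.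

Compound 4 `O=C(Nc1ccc(OC(F)(F)F)cc1)NC1CCN(C(=O)c2ccoc2)CC1` has not yet been measured. It differs from compound 3 by trifluoromethoxy in place of trifluoromethyl on an aromatic carbon. Within the data shown here, this is the same kind of change as the one from compound 1 to compound 2, though the surroundings are not identical: in compound 1 the leaving group sits ortho to a fluoro group, while in compound 3 no fluoro group is present on that ring.

From the step seen between compound 1 and compound 2, the step from compound 3 to compound 4 in this assay is expected to be a number 0.33 log units higher from compound 3 to compound 4 (beyond the scatter), resting on the assumption that the swap behaves alike on the second core. On that basis compound 4 is expected to give about 3.83, with a likely range from 3.5 to 4.2.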

Compound 4, partition coefficient: 3.63
Estimate against measurement, compound 4: 0.20 log units above; low and high end bracket the measured number.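

In this assay, putting trifluoromethoxy in place of trifluoromethyl gives a number 0.13 log units higher from compound 3 to compound 4 (within the scatter), while the same swap on the core of compound 1 gave a number 0.33 log units higher from compound 1 to compound 2 (beyond the scatter). So the swap does not transfer as a dependable step in this series: a step that stood clear of the usual scatter on one core cannot be told apart from that scatter on the other, and a number measured on one core is therefore a weak guide to the other. This does not show that the swap has no effect on the core of compound 3 or that the two cores truly respond differently, as only two pairs are shown, and no measurement given here explains the contrast between them.

Going by these compounds, the two pairs also differ from each other in more than one place, including the fluoro group carried by compound 1 and compound 2 but not by compound 3 or compound 4, so the part of the structure that matters for the size of the step remains open. Also open, on these data alone, is how a methoxy group or a nitrile on that same aromatic carbon would read on either core.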